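Capping a Hydroxy Group with Methyl: Expected Cost in Potency

A few compounds are considered here, and "the series" means these few. Any claim that something is new, unique, unknown or untested is made for them only; others in the source may bear on it.

Of the compounds shown here, three have so far been tested in a functional assay on A549 cells (Homo sapiens) for antiproliferative activity, read by MTT assay, with a stated time of 48 h; on this read-out higher numbers stand for weaker inhibition and lower numbers for stronger inhibition. Compound 1, `COc1ccc(-c2nn(-c3ccccc3)cc2C(=O)/C=C\Nc2ccc(O)cc2)cc1`, gives 2770 nM. Compound 2, `COc1ccc(N/C=C\C(=O)c2cn(-c3ccccc3)nc2-c2ccc(OC)cc2)cc1`, gives 6780 nM. The only difference between these two is methyl in place of hydrogen on an oxygen on an aromatic ring, and that change produced a 2.4-fold higher number from compound 1 to compound 2 (0.39 log units; beyond the scatter), a modest but real weakening. For the measured compounds named here, compound 3, `COc1cc(-c2nn(-c3ccccc3)cc2C(=O)/C=C\Nc2ccc(O)cc2)cc(OC)c1OC`, gives 3160 nM, a number that lies close to the one for compound 1; the difference between the core of compound 3 and the core of compound 1 is not broken down here.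

Compound 4, `COc1ccc(N/C=C\C(=O)c2cn(-c3ccccc3)nc2-c2cc(OC)c(OC)c(OC)c2)cc1`, has not yet been measured. It relates to compound 3 through (methyl in place of hydrogen on an oxygen on an aromatic ring), which is the same change already seen between compound 1 and compound 2, at the same kind of place on the molecule. Because a 2.4-fold higher number from compound 1 to compound 2 (0.39 log units; beyond the scatter) followed that change once, a weakening of similar size is expected here, namely a 2.3-fold higher number from compound 3 to compound 4 (0.36 log units; beyond the scatter). On this basis compound 4 is expected to give about 7200 nM, most likely falling between 3600 nM and 14500 nM. A single earlier example is thin evidence, so the range is kept wide.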

Compound 4, half-maximal inhibitory concentration: 4780 nM
Compound 4: the middle estimate sits 1.5-fold (0.18 log units) above what was measured; the measured number falls inside the stated range.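

In this assay, replacing hydroxy with methoxy on the second core gave a 1.5-fold higher number from compound 3 to compound 4 (0.18 log units; within the scatter), so this step alone does not establish a real loss of potency. Set beside the earlier example, the two steps cannot be told apart: the same change on two cores in this assay, a 2.4-fold higher number (0.39 log units; beyond the scatter) from compound 1 to compound 2 and a 1.5-fold higher number (0.18 log units; within the scatter) from compound 3 to compound 4, 1.6-fold (0.21 log units) apart, within the scatter of two such steps This agreement is compatible with the change carrying over between these two cores, but two pairs cannot prove that it does or fix its size, and the swap of the aryl group on the methoxy compounds, with a 1.4-fold lower number from compound 2 to compound 4 (0.15 log units; within the scatter), likewise shows no difference beyond the scatter.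

The compounds shown leave open whether an ethyl group or a longer chain on that oxygen, or an amine in place of the hydroxy group, would give numbers like those seen with methyl. They also leave open whether the hydroxy-to-methoxy step would behave in the same way on any core beyond these two.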